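The source may hold more compounds than are shown below. What is called first, only, known or untested is meant among the compounds shown, and "the series" means these compounds.

Measured in a functional assay on HepG2 cells (Homo sapiens) for inhibition, read by MTT assay, with a stated time of 48 h; on this read-out higher numbers stand for weaker inhibition and lower numbers for stronger inhibition:
- compound 1 `CCOC(=O)C1=C(N/C=N/c2cccnc2Cl)Nc2[nH]nc(C)c2C1c1ccc(N(C)C)cc1`: 4890 nM
- compound 2 `CCOC(=O)C1=C(NN=C(C(C)=O)C(C)=O)Nc2[nH]nc(C)c2C1c1ccc(N(C)C)cc1`: 8480 nM
- compound 3 `CCOC(=O)C1=C(N/N=C(/C(=O)Br)c2ccc(Br)cc2)Nc2[nH]nc(C)c2C1c1ccc(N(C)C)cc1`: 65000 nM

Compound 3 has the highest number of the three, and so the weakest inhibition. Compound 4 `CCOC(=O)C1=C(NN=C(C#N)C#N)Nc2[nH]nc(C)c2C1c1ccc(N(C)C)cc1` differs from it by a group of 6 heavy atoms (3 carbon, 3 nitrogen; no ring) in place of a group of 12 heavy atoms (8 carbon, 1 nitrogen, 1 oxygen, 2 bromine; one six-membered aromatic ring of carbon only), on an amine nitrogen. The entering group has no ring and carries 2 triple bonds.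

The relevant steps are a 7.7-fold higher number from compound 2 to compound 3 (0.88 log units; beyond the scatter) and a 13-fold higher number from compound 1 to compound 3 (1.12 log units; beyond the scatter), whereas a 1.7-fold higher number from compound 1 to compound 2 (0.24 log units; within the scatter) stays within the scatter. Compound 2 also lacks a ring in this group, but compound 1 goes against any ring rule. A return towards compound 2 is therefore expected, with a modest drop in this assay. The estimated step is a 5.9-fold lower number from compound 3 to compound 4 (0.77 log units; beyond the scatter). For compound 4 the expected value is 11000 nM, with an estimated range of 3500 nM to 35000 nM.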

Compound 4, half-maximal inhibitory concentration: 13700 nM
Beside the measured number, compound 4's estimate is 1.2-fold (0.10 log units) below it; the range from low to high includes it.
By their numbers in this assay, from the lowest: compounds 1, 2 and 4 (each within the scatter of the next, the first and the last beyond it); then compound 3.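

In this assay, a second ring-free group on this amine nitrogen, this one with 2 triple bonds, also gives a clear gain over the bromine-bearing group of compound 3 (a 4.7-fold lower number from compound 3 to compound 4 (0.68 log units; beyond the scatter)). Against the other ring-free group, the change stays within the scatter (a 1.6-fold higher number from compound 2 to compound 4 (0.21 log units; within the scatter)). Compound 1 keeps its ring yet remains ahead (a 2.8-fold higher number from compound 1 to compound 4 (0.45 log units; beyond the scatter)), so the absence of a ring does not by itself set the number.

From the compounds shown here alone, how a plain phenyl group or a carboxylic acid would read at this nitrogen remains open. Nothing available gives a cause for these steps.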